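The compounds below may be only part of what the source reports. "The series", "measured", "known", "first", "only" and "open" are said of these compounds alone.

In a functional assay on MCF7 cells (Homo sapiens) for cytotoxicity, read by MTT assay, with a stated time of 72 h (on this read-out higher numbers stand for weaker inhibition and lower numbers for stronger inhibition), compound 1 `O=C(N/N=C/c1ccc([N+](=O)[O-])cc1)Nc1cc2c(Nc3ccc(F)c(Cl)c3)ncnc2cc1O[C@H]1CCOC1` is reported as "not active" (no number reported), with no number attached. Going by the values given here, compound 2 `O=C(N/N=C/c1ccc(O)c(Br)c1)Nc1cc2c(Nc3ccc(F)c(Cl)c3)ncnc2cc1O[C@H]1CCOC1` gives 2690 nM, the only number so far, so it can be ranked against no other numerical value. Compound 3 `O=C(N/N=C/c1cc(Br)c(O)c(Br)c1)Nc1cc2c(Nc3ccc(F)c(Cl)c3)ncnc2cc1O[C@H]1CCOC1` is still to be measured and differs from compound 2 by a single change: bromo in place of hydrogen on an aromatic carbon. This is bromo in place of hydrogen on an aromatic carbon, taking 3-bromo-4-hydroxyphenyl to 3,5-dibromo-4-hydroxyphenyl. Among the compounds with values here, no measured pair shows this change, or any other single change, so the data give no direct guide to its size. The estimated step is a 1.5-fold lower number from compound 2 to compound 3 (0.17 log units; within the scatter), an expected small move toward stronger inhibition that stays within the usual scatter. The expected value for compound 3 is 1800 nM, with an estimated range from 500 nM to 6500 nM.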

Compound 3, half-maximal inhibitory concentration: 5910 nM
Compound 3: middle estimate off by 3.3-fold (0.52 log units), on the low side, and the stated range covers the measured number.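

In this assay the pair gives the series its first single-change reading: bromo in place of hydrogen on an aromatic carbon, ortho to a hydroxy group, gives a 2.2-fold higher number from compound 2 to compound 3 (0.34 log units; beyond the scatter) and so moves the read-out toward weaker inhibition. The step is modest but beyond the scatter, which shows that this position responds to one added bromo group when 3-bromo-4-hydroxyphenyl becomes 3,5-dibromo-4-hydroxyphenyl. No measurement at hand offers an explanation for this shift.

On these data alone, whether a smaller chloro or fluoro group, or an amine, at the same position would shift the read-out in the same direction remains open. Also open, as far as these compounds go, is how the 3,5-dibromo-4-hydroxyphenyl group would respond to a methoxy group in place of its hydroxy group.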